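Neopentylamino in place of propylamino on the shared core

The source may report more compounds than this note shows. Statements on the series, on what has been measured and on what is new or still open speak of the compounds shown alone.

Measured so far in an in vitro assay on IMR-32 cells for displacement of a labelled ligand from corticotropin-releasing factor receptor 1 (Homo sapiens); a higher number here means a weaker inhibitor, a lower number a stronger inhibitor:
Compound 1 `CCCN(CCC)c1c(C)nc(-c2c(C)cc(C)cc2OC)nc1OC(C)C` gives > 5000 nM, a limit of the assay.
Compound 2 `CCCN(CCC)c1c(CC(C)(C)O)nc(-c2c(C)cc(C)cc2OC)nc1OC` gives 604 nM.
Compound 3 `CCCNc1c(C)nc(-c2c(C)cc(C)cc2OC)nc1OC` gives > 10000 nM, a limit of the assay.

Compound 3 stands at a bound of this assay rather than at a number; of the three values shown, only compound 2 carries a measured figure. Compound 4 `COc1cc(C)cc(C)c1-c1nc(C)c(NCC(C)(C)C)c(OC)n1` differs from compound 3 by tert-butyl in place of ethyl on a saturated chain carbon bound to a nitrogen on an aromatic ring. No step between measured compounds covers this change, so nothing on the shown compounds sets its size. With compound 3 sitting at the limit of > 10000 nM in this assay, at which 1 of the 3 values shown sits, the step of an at least 1.2-fold lower number from compound 3 to compound 4 (0.09 log units; that floor lies within the scatter) is expected to be small and may not rise beyond the scatter, with a fair chance that only a limit is reported again. Compound 4 is estimated at 8000 nM, within 2000 nM to 30000 nM.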

Compound 4, inhibition constant: > 10000 nM
Compound 4: no number, only a limit; the forecaster's own chance of this, stated with the estimate: 55%; middle value at least 1.2-fold (0.09 log units) from the limit.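

Compound 3 and compound 4 both stand at a limit of the assay, so no step can be read between them. The compounds shown leave open whether neopentylamino in place of propylamino changes the inhibition constant at all.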